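From Methyl to Isopropyl in a Small Series

A few compounds are considered here, and "the series" means these few. Any claim that something is new, unique, unknown or untested is made for them only; others in the source may bear on it.

Within the data shown here, in a functional assay on HepG2 cells (Homo sapiens) for antiproliferative activity, read by CCK-8 assay, with a stated time of 72 h (a higher number here means a weaker inhibitor, a lower number a stronger inhibitor), compound 3 `Cc1ccc(OCc2ccc(C(=O)Nc3ccccc3N)cc2)cc1` gives 6590 nM and stands with compound 2 `CCc1ccc(OCc2ccc(C(=O)Nc3ccccc3N)cc2)cc1` at 6960 nM as the only two numbers in hand. The pair shows a 1.1-fold lower number from compound 2 to compound 3 (0.02 log units; within the scatter) and so gives no order. Compound 1 `Nc1ccccc1NC(=O)c1ccc(COc2ccc(Br)cc2)cc1` reads > 32000 nM as a limit of the assay and not a number.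

Compound 4 `CC(C)c1ccc(OCc2ccc(C(=O)Nc3ccccc3N)cc2)cc1` has isopropyl in place of methyl on an aromatic carbon, para to a large group. The change is isopropyl in place of methyl on an aromatic carbon and reads as 4-methylphenyl to 4-isopropylphenyl.

The closest measured step is a 1.1-fold lower number from compound 2 to compound 3 (0.02 log units; within the scatter) and it also concerns the alkyl group at this place. The steps of an at least 4.5-fold lower number from compound 1 to compound 2 (0.66 log units; beyond the scatter) and an at least 4.8-fold lower number from compound 1 to compound 3 (0.68 log units; beyond the scatter) lie beyond the scatter, but they start from a limit and replace bromo, so they carry less weight here. Among the measured compounds shown here, only two measured compounds bear on alkyl size, and neither carries isopropyl. The range is therefore left wider towards higher numbers.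

The expected size is a 1.1-fold higher number from compound 3 to compound 4 (0.06 log units; within the scatter) and no step beyond the scatter is expected. In this assay compound 4 is estimated at 7500 nM with an expected range from 3800 nM to 18000 nM on this reading.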

Compound 4, half-maximal inhibitory concentration: > 32000 nM
Compound 4: a limit, no number; the forecaster's own chance of this, stated with the estimate: 8%; middle value at least 4.2-fold (0.63 log units) away from the limit.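

In this assay, this position no longer reads as indifferent to the alkyl group: isopropyl gives an at least 4.8-fold higher number from compound 3 to compound 4 (0.68 log units; beyond the scatter), and the comparison with ethyl gives an at least 4.5-fold higher number from compound 2 to compound 4 (0.66 log units; beyond the scatter). Methyl and ethyl stood within the scatter of each other, so the flat reading across those two groups does not carry over to 4-isopropylphenyl, although the change from methyl adds only carbon, with no ring, no hydrogen-bond donor or acceptor and no net charge. The step between compound 1 and compound 4 cannot be read: the limit of > 32000 nM in this assay, at which 2 of the 4 values shown sit.

On these data alone, how the loss relates to branching as against the carbon count of the group stays open, and a straight propyl chain, a cyclopropyl group or a tert-butyl group at this position would separate the two readings. Whether the position accepts anything other than a small alkyl group also stays open, since the only non-alkyl group shown is bromo, and a methoxy group or an amine here would test that.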